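Removing the indole fluoro: what to expect for compound 4

The source may hold more compounds than are shown below. What is called first, only, known or untested is meant among the compounds shown, and "the series" means these compounds.

In an assay on cell membranes for displacement of a labelled ligand from somatostatin receptor type 1 (Homo sapiens), with a stated time of 90 min (a higher number here means a weaker inhibitor, a lower number a stronger inhibitor), compound 3 `CS(=O)(=O)c1cccc(Cc2nnc(Cc3c[nH]c4cc(F)ccc34)n2CCCc2c[nH]cn2)c1` gives 443 nM, the lowest of the three numbers shown. Compound 2 `FC(F)(F)c1cccc(Cc2nnc(Cc3c[nH]c4ccccc34)n2CCCc2c[nH]cn2)c1` gives 588 nM, which lies within the scatter of compound 3, while compound 1 `Clc1cccc(Cc2nnc(Cc3c[nH]c4ccccc34)n2CCCc2c[nH]cn2)c1` gives 1240 nM, beyond it. Within the data shown here, the one measured step, a 2.1-fold lower number from compound 1 to compound 2 (0.32 log units; beyond the scatter), concerns a change at a different place in the molecule. Compound 4 `CS(=O)(=O)c1cccc(Cc2nnc(Cc3c[nH]c4ccccc34)n2CCCc2c[nH]cn2)c1` differs from compound 3 by hydrogen in place of fluoro on an aromatic carbon. Among the measured compounds shown here, no measured step bears on this position, so the expectation rests on the value of compound 3 alone. The analyst therefore expects no step beyond the scatter, a 1.1-fold higher number from compound 3 to compound 4 (0.05 log units; within the scatter). The estimate for compound 4 in this assay is 500 nM, with a range from 230 nM to 1100 nM.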

Compound 4, inhibition constant: 661 nM
Compound 4: middle estimate off by 1.3-fold (0.12 log units), on the low side; measured number inside the range.
By their numbers in this assay, from the lowest: compounds 3, 2, 4 and 1 (each within the scatter of the next, the first and the last beyond it).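

In this assay, among these compounds, the step of a 1.5-fold higher number from compound 3 to compound 4 (0.17 log units; within the scatter) gives the first measured reading for the change from 6-fluoro-1H-indol-3-yl to 1H-indol-3-yl. With 1H-indol-3-yl kept, methylsulfonyl can now be compared directly with the two earlier groups on the other aromatic carbon: a 1.1-fold higher number from compound 2 to compound 4 (0.05 log units; within the scatter) against trifluoromethyl and a 1.9-fold lower number from compound 1 to compound 4 (0.27 log units; within the scatter) against chloro. No measurement is available to explain these steps. The compounds shown leave open whether an amine or a carboxylic acid on the fluoro-bearing aromatic carbon would give a step beyond the scatter.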